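A few compounds are considered here, and "the series" means these few. Any claim that something is new, unique, unknown or untested is made for them only; others in the source may bear on it.

Of the compounds shown here, three have been measured in a functional assay on MCF7 cells (Homo sapiens) for antiproliferative activity; on this read-out higher numbers stand for weaker inhibition and lower numbers for stronger inhibition. Compound 1 `FC(F)(F)c1ncnc2c1ncn2C1COc2ccccc2CO1` gives 1250 nM in this assay, compound 2 `COC(CNc1ccccc1CO)n1cc(F)c(=O)[nH]c1=O` gives 36000 nM, and compound 3 `c1ccc(Sc2ncnc3ncn(C4CNc5ccccc5CO4)c23)cc1` gives 48900 nM. Compound 3 thus stands at the highest of the three numbers; its nearest neighbour is compound 2, whose number lies within the usual scatter of that of compound 3, while compound 1 lies furthest away, with a lower number beyond the scatter. Compound 4 `O=[N+]([O-])c1ccc(S(=O)(=O)N2CC(n3cnc4ncnc(Sc5ccccc5)c43)OCc3ccccc32)cc1` has not yet been measured in this assay. It differs from compound 3 in one place: (4-nitrophenyl)sulfonyl in place of hydrogen on a nitrogen on an aromatic ring in a ring. Among the measured compounds shown here, no step between measured compounds bears on a change of this kind, so the expectation rests on compound 3 alone. The step in this assay is estimated as a 1.6-fold lower number from compound 3 to compound 4 (0.21 log units; within the scatter), a small move towards a lower number that may well fall within the scatter. For compound 4 the estimated value in this assay is 30000 nM, with a range from 8000 nM to 100000 nM.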

Compound 4, half-maximal inhibitory concentration: 860 nM
Compound 4: middle estimate off by 35-fold (1.54 log units), on the high side, and the stated range ends above it.
By their numbers in this assay, from the lowest: compounds 4 and 1 (each within the scatter of the next); then compounds 2 and 3 (each within the scatter of the next).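

In this assay, the nitrogen of the seven-membered non-aromatic ring proves to be a place where a substituent can move the number a long way: (4-nitrophenyl)sulfonyl in place of hydrogen gives a 57-fold lower number from compound 3 to compound 4 (1.75 log units; beyond the scatter), a large step beyond the scatter. Among the compounds shown here, the earlier compounds held no step at this nitrogen, so this is the first sign that a large group is tolerated there and goes with stronger inhibition. Nothing measured here accounts for the size of this step.

The compounds shown leave open whether the step belongs to the sulfonyl link or to the 4-nitrophenyl ring, which a methylsulfonyl or a benzoyl group at this nitrogen would help to separate. They also leave open whether the nitro group itself matters, as an amine or a nitrile in its place on the ring would show.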